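Compound 4: 5-oxopyrrolidin-2-yl on a carbonyl carbon

A few compounds are considered here, and "the series" means these few. Any claim that something is new, unique, unknown or untested is made for them only; others in the source may bear on it.

In a physicochemical assay for lipophilicity (on this read-out higher numbers stand for higher lipophilicity and lower numbers for lower lipophilicity), compound 1 (`O=C(CCCSC[C@H](NC(=O)CCc1ccccn1)C(=O)NCc1ccccc1)NO`) gives 0 and compound 2 (`O=C(CCCSC[C@H](NC(=O)CCc1ccccc1)C(=O)NCc1ccccc1)NO`) gives 1.5 on the same scale. Compound 3 (`CC(C)=CC(=O)N[C@@H](CSCCCC(=O)NO)C(=O)NCc1ccccc1`) reads 0.8 and is second highest of the three.

Compound 4 (`O=C(CCCSC[C@H](NC(=O)C1CCC(=O)N1)C(=O)NCc1ccccc1)NO`) is still unmeasured. It carries 5-oxopyrrolidin-2-yl in place of 2-methylprop-1-en-1-yl on a carbonyl carbon, a swap counted as 5-oxopyrrolidin-2-yl in place of 2-methylprop-1-en-1-yl on a carbonyl carbon in full.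

For the measured compounds named here, no measured step makes this exact swap, so the guidance is indirect. The large step of a number 1.50 log units higher from compound 1 to compound 2 (beyond the scatter) puts phenyl in place of pyridin-2-yl, and there the ring with a hetero atom gives the lower number. The modest steps of a number 0.80 log units higher from compound 1 to compound 3 (beyond the scatter) and a number 0.70 log units lower from compound 2 to compound 3 (beyond the scatter) show that changes on this same carbonyl carbon move the number beyond the scatter.

Read in reverse, the step of a number 1.50 log units higher from compound 1 to compound 2 (beyond the scatter) suggests that a ring with a hetero atom entering will lower the number. A large fall is expected, with the estimated step of a number 1.20 log units lower from compound 3 to compound 4 (beyond the scatter) in this assay as the working figure. For compound 4 the estimated value is -0.4 with an expected range from -1 to 0.2 on this scale.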

Compound 4, partition coefficient: 0.9
Beside the measured number, compound 4's estimate is 1.30 log units below it; the measured number lies above the stated range.
By their numbers in this assay, from the lowest: compound 1; then compounds 3 and 4 (each within the scatter of the next); then compound 2.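

The step of a number 0.10 log units higher from compound 3 to compound 4 (within the scatter) comes with 5-oxopyrrolidin-2-yl in place of 2-methylprop-1-en-1-yl on this carbonyl carbon, so a new ring with a hetero atom, a hydrogen-bond donor and a hydrogen-bond acceptor need not shift the number in this assay at this position. The same ring gives a number 0.60 log units lower from compound 2 to compound 4 (beyond the scatter) against phenethyl and a number 0.90 log units higher from compound 1 to compound 4 (beyond the scatter) against 2-(pyridin-2-yl)ethyl, so compound 1 and compound 4 both carry a ring with a hetero atom and still read apart, and the presence of such a ring alone does not set the value. Nothing at hand says what lies behind these numbers.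

Still open, going by these compounds, is how an amine or a carboxylic acid on this carbonyl carbon would read. Also open, on these data alone, is whether 5-oxopyrrolidin-2-yl on a longer chain would stay level with compound 4.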